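The source may hold more compounds than are shown below. What is called first, only, known or untested is meant among the compounds shown, and "the series" means these compounds.

Compound 1: `O=C(O)CCCCCOc1cc(-c2ccccc2Cl)cc(-c2ccccc2)n1` — > 10000 nM
Compound 2: `CC(CCCCOc1cc(-c2ccccc2)cc(-c2ccccc2)n1)C(=O)O` — 22 nM

Both measured compounds were tested in a functional assay on cells for inhibition of leukotriene B4 receptor 1 (Homo sapiens); on this read-out lower numbers stand for stronger inhibition and higher numbers for weaker inhibition. For compound 1 the result is only a limit of the assay and not a number, namely > 10000 nM; this is the limit of > 10000 nM in this assay, at which 1 of the 2 values shown sits. Compound 2 gives 22 nM. Going by the values given here, compound 1 and compound 2 differ in more than one place, so no single step joins them; their two values show only that compound 2 yields a number where compound 1 yields none.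

Compound 3 is `O=C(O)CCCCCOc1cc(-c2ccc(C(F)(F)F)cc2)cc(-c2ccccc2)n1`. It differs from compound 1 in one place: 4-(trifluoromethyl)phenyl in place of 2-chlorophenyl on an aromatic carbon. Among the compounds with values here, no measured pair shows a change of this kind, so the size of the step in this assay can only be estimated. A move toward stronger inhibition is expected, though its size is uncertain. The step from compound 1 to compound 3 is estimated as an at least 3.3-fold lower number from compound 1 to compound 3 (0.52 log units; beyond the scatter). For compound 3 the expected value is 3000 nM, estimated to lie between 300 nM and 30000 nM, with a real chance that the assay again reports only a limit.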

Compound 3, half-maximal inhibitory concentration: 10000 nM
Estimate against measurement, compound 3: 3.3-fold (0.52 log units) below; the range from low to high includes it.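

With 4-(trifluoromethyl)phenyl on the carbon opposite the ring nitrogen, compound 3 gives an actual number in this assay, 10000 nM, whereas the 2-chlorophenyl of compound 1 yielded none. The swap gives a number no higher from compound 1 to compound 3 (the limit leaves the size open) and the size of this change cannot be read, because one end of it is only a limit: the limit of > 10000 nM in this assay, at which 1 of the 3 values shown sits. So the swap shows that this position accepts a group with more heavy atoms and still gives a measurable result, but the number remains high, which on this read-out means weak inhibition, and the pair cannot say how much was gained.

The compounds shown leave open what a plain phenyl at this position would give on the same (5-carboxypentyl)oxy chain, a single change that would show whether either substituted ring helps or hurts relative to the unsubstituted one. On these data alone, it also remains open whether a nitrile or an amine in place of the trifluoromethyl would move the value, which would begin to separate the effect of that particular group from the effect of simply having something on the ring.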